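A few compounds are considered here, and "the series" means these few. Any claim that something is new, unique, unknown or untested is made for them only; others in the source may bear on it.

Measured so far:
compound 1, `C[C@H](NC(=O)[C@H](C)[C@H]1CC[C@@H](c2ccnc3ccc(F)cc32)CC1)c1ccc(Cl)cc1`, 5% in an ADME assay on microsomes from liver (Mus musculus) for metabolic stability, with a stated time of 10 min, tested at 0.5 uM; on this read-out higher numbers stand for a more stable compound and lower numbers for a less stable compound
compound 2, `C[C@@H](C(=O)NC1CCCCC1)[C@H]1CC[C@@H](c2ccnc3ccc(F)cc32)CC1`, < 1% in this assay

Compound 2 sits at the lower limit of this assay, a limit rather than a number, which is the case for (the limit of < 1% in this assay, at which 1 of the 2 values shown sits). Its value therefore gives only a ceiling. Compound 3, `C[C@@H](NCc1ccc(Cl)cc1)[C@H]1CC[C@@H](c2ccnc3ccc(F)cc32)CC1`, differs from compound 2 by (4-chlorobenzyl)amino in place of cyclohexylcarbamoyl on a saturated chain carbon bound to a saturated chain carbon and a saturated ring carbon. Among the compounds with values here, the one measured step, a number at least 4 percentage points lower from compound 1 to compound 2 (that floor lies within the scatter), concerns a swap on the amide nitrogen and bears only loosely on a change that removes the amide and brings in an amine. Compound 3 is expected to move by a number at least 4 percentage points higher from compound 2 to compound 3 (that floor lies within the scatter), a rise that stays within the scatter. Compound 3 is estimated at 5%, between 0% and 20%.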

Compound 3, percent of the compound remaining: 2%
The estimate for compound 3 lay 3 percentage points above the measured number; the range from low to high includes it.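

Moving the change from the amide-type nitrogen to a saturated chain carbon bound to a saturated chain carbon and a saturated ring carbon, (4-chlorobenzyl)amino in place of cyclohexylcarbamoyl gives a number at least 1 percentage points higher from compound 2 to compound 3 (that floor lies within the scatter). Removing the carbonyl here therefore shows no gain in this assay that stands clear of the scatter. Compound 2 stands at a limit, so the step has only a floor: the limit of < 1% in this assay, at which 1 of the 3 values shown sits.

The compounds shown leave open how a carboxylic acid or a longer chain on this carbon would read in this assay.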